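Swapping chloro for fluoro on the pendant phenyl ring

A few compounds are considered here, and "the series" means these few. Any claim that something is new, unique, unknown or untested is made for them only; others in the source may bear on it.

Three compounds that share one core have been examined in a functional assay on LNCaP cells (Homo sapiens) for cytotoxicity, read by MTT assay, with a stated time of 48 h; on this read-out higher numbers stand for weaker inhibition and lower numbers for stronger inhibition. Compound 1 `Cc1ccc(-c2ccnc(Nc3ccc4c(c3)c(/C=C3/C(=O)Nc5ccccc53)cn4C)n2)cc1` carries a methyl on its phenyl ring; in this assay compound 1 gives only a limit, > 100000 nM. Compound 2 `Cn1cc(/C=C2/C(=O)Nc3ccccc32)c2cc(Nc3nccc(-c4ccc(O)cc4)n3)ccc21`, with a hydroxy in that place, gives 10800 nM in this assay. Compound 3 `Cn1cc(/C=C2/C(=O)Nc3ccccc32)c2cc(Nc3nccc(-c4ccc(Cl)cc4)n3)ccc21`, with a chloro, gives 6590 nM in this assay and so holds the lowest of the two numbers reported, though its step from compound 2 is a 1.6-fold lower number from compound 2 to compound 3 (0.21 log units; within the scatter), so the two cannot be ranked. The step from the methyl compound is larger: an at least 15-fold lower number from compound 1 to compound 3 (1.18 log units; beyond the scatter), and likewise an at least 9.2-fold lower number from compound 1 to compound 2 (0.96 log units; beyond the scatter).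

Compound 4 `Cn1cc(/C=C2/C(=O)Nc3ccccc32)c2cc(Nc3nccc(-c4ccc(F)cc4)n3)ccc21` has not yet been measured. It differs from compound 3 by fluoro in place of chloro on an aromatic carbon. Among the compounds with values here, the steps that bear on this are the two that alter the same position: hydroxy to chloro moved the number by a 1.6-fold lower number from compound 2 to compound 3 (0.21 log units; within the scatter), while methyl to chloro gave a large change that rests on the limit (the limit of > 100000 nM in this assay, at which 1 of the 3 values shown sits). A second halogen in place of the first is expected to sit close to compound 3, perhaps slightly higher, within the scatter: the estimated step is a 1.4-fold higher number from compound 3 to compound 4 (0.14 log units; within the scatter). Compound 4 is therefore expected to give about 9000 nM in this assay, within 4000 nM to 25000 nM.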

Compound 4, half-maximal inhibitory concentration: 16300 nM
Estimate against measurement, compound 4: 1.8-fold (0.26 log units) below, within the range that was stated.
By their numbers in this assay, from the lowest: compounds 3, 2 and 4 (each within the scatter of the next, the first and the last beyond it). At a limit, above all of these: compound 1.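

In this assay, this position now separates two substituents, which the hydroxy-to-chloro step had not done: the exchange of 4-chlorophenyl for 4-fluorophenyl gives a 2.5-fold higher number from compound 3 to compound 4 (0.39 log units; beyond the scatter), so even a swap of one halogen for the other can be read at this place. The hydroxy compound does not fall clearly on either side, since a 1.5-fold higher number from compound 2 to compound 4 (0.18 log units; within the scatter), and the earlier step placed it within the scatter of compound 3 as well, so compound 2 cannot be ranked against either halogen compound even though those two stand apart. Fluoro also stands clear of methyl, with an at least 6.1-fold lower number from compound 1 to compound 4 (0.78 log units; beyond the scatter), so the methyl compound remains the outlier among the four, but the true size of that step stays undefined, for it rests on a limit: the limit of > 100000 nM in this assay, at which 1 of the 4 values shown sits.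

The compounds shown leave open whether a bromo or a methoxy at this place would fall with chloro, with fluoro or nearer to methyl. They also leave open how an amine or a carboxylic acid on the same ring would read, and the four values alone give no reason for the gap between the two halogens.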